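Swapping the amine on the benzamide of a steryl-sulfatase inhibitor

A few compounds are considered here, and "the series" means these few. Any claim that something is new, unique, unknown or untested is made for them only; others in the source may bear on it.

Measured compounds:
compound 1, `NS(=O)(=O)Oc1ccc2c(c1)CN(C(=O)c1cccc(N3CCC(N4CCCCC4)CC3)c1)CC2`, 8%
compound 2, `CCN(Cc1ccncc1)c1ccc(C(=O)N2CCc3ccc(OS(N)(=O)=O)cc3C2)cc1`, 86.6%
compound 3, `CN(CCCN1CCCCC1)c1cccc(C(=O)N2CCc3ccc(OS(N)(=O)=O)cc3C2)c1`, 30.6%

Of the compounds shown here, three sharing the same sulfamate-bearing core have been tested in an assay on HEK293 cells for inhibition of Steryl-sulfatase (Homo sapiens), tested at 1 uM; a lower number here means a weaker effect, a higher number a stronger effect of the compound at the concentration tested. Compound 2 stands highest of the three numbers: compound 3 comes nearest, with a value that is lower by a gap beyond the scatter, and compound 1 lies furthest, with a value lower by a gap that is also beyond the scatter.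

The next compound is compound 4, `CN(CCCN1CCCCC1)c1ccc(C(=O)N2CCc3ccc(OS(N)(=O)=O)cc3C2)cc1`. It differs from compound 2 in one place, (methyl(3-(piperidin-1-yl)propyl)amino in place of ethyl((pyridin-4-yl)methyl)amino on an aromatic carbon). Among the measured compounds shown here, no step between two measured compounds isolates this change, so no size can be read off directly. What the numbers do show is that compound 3, which also bears methyl(3-(piperidin-1-yl)propyl)amino, gives 30.6% in this assay, well under the value of compound 2.

On that basis a downward step is expected, a number 46.6 percentage points lower from compound 2 to compound 4 (beyond the scatter), clearly beyond the scatter. Compound 4 is therefore estimated at 40% in this assay, with a range from 15% to 70%.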

Compound 4, a percentage reported as inhibition, at one concentration (the size of the read-out at that concentration, not a potency): 40.7%
Compound 4: the middle estimate sits 0.7 percentage points below what was measured, within the range that was stated.
By their numbers in this assay, from the lowest: compound 1; then compound 3; then compound 4; then compound 2.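

The swap of ethyl((pyridin-4-yl)methyl)amino for methyl(3-(piperidin-1-yl)propyl)amino, on the aromatic carbon para to a large group, can now be read directly in this assay as a number 45.9 percentage points lower from compound 2 to compound 4 (beyond the scatter). Among the compounds shown here, this is the first step measured at this position, and it shows that the change costs much of the inhibition even though the counts of hydrogen-bond donors and acceptors stay the same and neither group carries a net charge. The groups differ in ring type, one six-membered aromatic and the other six-membered non-aromatic, and in their chains, but no information is available to explain the drop.

With both parts changing at once, the ring and the chain cannot be separated. A benzyl group in place of the (pyridin-4-yl)methyl part, or a morpholine ring in place of the piperidine at the end of the propyl chain, would help to tell which part matters.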